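Extending the Acetyl Cap of a Legumain Inhibitor

The compounds below may be only part of what the source reports. "The series", "measured", "known", "first", "only" and "open" are said of these compounds alone.

For the measured compounds named here, compound 1 `CCOC(=O)/C=C/C(=O)N(CC(N)=O)NC(=O)[C@@H]1CCCN1C(C)=O` is the stronger of the two compounds measured so far: in an assay on isolated protein for inhibition of legumain (Mus musculus), read by fluorescence, with stated times of 30 s and 2.5 h (on this read-out lower numbers stand for stronger inhibition and higher numbers for weaker inhibition), compound 1 gives 8.3 nM, the lowest number of the two. Compound 2 `C/C=C(\NC(C)=O)C(=O)N1CCC[C@H]1C(=O)NN(CC(N)=O)C(=O)/C=C/C(=O)OCC` shares its core, and in this assay compound 2 gives 141 nM. The step between them, a 17-fold higher number from compound 1 to compound 2 (1.23 log units; beyond the scatter), came from a larger group in place of one carbon atom on a carbonyl carbon. Compound 3 `C#CC[C@H](NC(C)=O)C(=O)N1CCC[C@H]1C(=O)NN(CC(N)=O)C(=O)/C=C/C(=O)OCC` changes compound 1 at the same place: a group of 8 heavy atoms (6 carbon, 1 nitrogen, 1 oxygen; no ring) in place of one carbon atom, on a carbonyl carbon. Going by the values given here, the only measured step that bears on this is the one from compound 1 to compound 2, which was large and toward weaker inhibition. Among the compounds with values here, a step of the same kind, toward weaker inhibition, is therefore expected here, though its size is uncertain; only one comparison exists. The expected step is a 7.2-fold higher number from compound 1 to compound 3 (0.86 log units; beyond the scatter). Compound 3 is estimated at 60 nM, within a range of 15 nM to 250 nM.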

Compound 3, half-maximal inhibitory concentration: 17 nM
For compound 3 the middle estimate is 3.5-fold (0.55 log units) above the measured one; the measured number falls inside the stated range.
By their numbers in this assay, from the lowest: compound 1; then compound 3; then compound 2.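

In this assay, a much larger group on this carbonyl carbon does not have to cost much: there is a 2.0-fold higher number from compound 1 to compound 3 (0.31 log units; beyond the scatter), a modest step, though one beyond the scatter. Compound 2 had suggested a heavier penalty, yet two groups of similar size at this same place give clearly different numbers, with an 8.3-fold lower number from compound 2 to compound 3 (0.92 log units; beyond the scatter), so at this position the make-up of the group counts and not only its size. No supporting measurement is available to explain the difference between these two groups.

The compounds shown leave open whether the triple bond, the defined stereocentre or the chain itself separates compound 3 from compound 2. They also leave open how a longer chain, an amine or a carboxylic acid at the end of the group would fare on this carbonyl carbon.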